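Vero cell toxicity: from compound 2 to compound 4

This account rests on a few compounds, and the source may have more. Where it says the series, first, only, none or still open, it means among the compounds named here.

Measured in an ADME assay on Vero cells (Chlorocebus sabaeus) for cytotoxicity, read by MTT assay; on this read-out higher numbers stand for lower toxicity in this test and lower numbers for higher toxicity in this test:
- compound 1 `COc1ccc(-c2nc3cc(C)ccn3c2Nc2cc(OC)c(OC)c(OC)c2)cc1O`: 48000 nM
- compound 2 `COc1cc(Nc2c(-c3cccc(O)c3)nc3cnccn23)cc(OC)c1OC`: 63000 nM
- compound 3 `COc1ccc(Nc2c(-c3ccc(F)cc3)nc3cnccn23)cc1`: 72000 nM

Compound 2, at 63000 nM, lies within the scatter of both other compounds, so the three values do not separate. The next compound to be tested is compound 4 `COc1cc(Nc2c(C3C=Nc4ccccc43)nc3cnccn23)cc(OC)c1OC`. Its change from compound 2 is a group of 9 heavy atoms (8 carbon, 1 nitrogen; one five-membered non-aromatic ring with 1 hetero atom, one six-membered aromatic ring of carbon only) in place of a group of 7 heavy atoms (6 carbon, 1 oxygen; one six-membered aromatic ring of carbon only), on an aromatic carbon. The 3-hydroxyphenyl group leaves an aromatic carbon of the shared core, and the larger group enters there.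

For the measured compounds named here, no measured pair differs in one place only, so the size of this change cannot be read directly from the data. Going by the values given here, the only guide is that compound 1 at 48000 nM and compound 3 at 72000 nM do not separate from compound 2, although their structures differ. The expected 1.3-fold lower number from compound 2 to compound 4 (0.10 log units; within the scatter) in this assay is therefore no step beyond the scatter, with a slight lean towards a lower number. Compound 4 is estimated at 50000 nM, with an expected range of 22000 nM to 100000 nM.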

Compound 4, concentration lethal to 50% of the cells: 70000 nM
Compound 4: middle estimate off by 1.4-fold (0.15 log units), on the low side; the range from low to high includes it.
By their numbers in this assay, from the lowest: compounds 1, 2, 4 and 3 (each within the scatter of the next).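

For the compounds shown here, at this aromatic carbon of the five-membered aromatic ring, this assay now gives a first step between compounds that differ in one place only: a 1.1-fold higher number from compound 2 to compound 4 (0.05 log units; within the scatter). On this read-out, the exchange of 3-hydroxyphenyl for the larger group, with its five-membered non-aromatic ring and 0 hydrogen-bond donors, does not separate the two compounds, so this one exchange at this position leaves the value within the scatter. Nothing at hand explains this result. 

As far as these compounds go, whether an amine or a carboxylic acid on this aromatic carbon would also stay within the scatter of compound 2 remains open. From the compounds shown here alone, compound 1 and compound 3 each differ from compound 2 in more than one place, so whether the same exchange would behave alike on their structures also remains open.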